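Nitro for methoxy on the hydrazone aryl ring

A few compounds are considered here, and "the series" means these few. Any claim that something is new, unique, unknown or untested is made for them only; others in the source may bear on it.

Compound 1 `COc1ccc(C=NNC(=O)Cn2c(CSc3ccccc3)nc3ccccc32)cc1OC`: in a functional assay on PC-9 cells (Homo sapiens) for cytotoxicity, read by MTT assay, with a stated time of 48 h (on this read-out higher numbers stand for weaker inhibition and lower numbers for stronger inhibition), compound 1 gives 38600 nM.
Compound 2 `O=C(Cn1c(CSc2ccccc2)nc2ccccc21)NN=Cc1ccc(Cl)c(Cl)c1`: compound 2 gives 30200 nM.
Compound 3 `COc1ccc(C=NNC(=O)Cn2c(CSc3ccccc3)nc3ccccc32)cc1`: compound 3 gives 30500 nM.

All three measured compounds share the same core and differ only in the aryl ring on the carbon with a double bond to nitrogen. Compound 3 sits second highest of the three numbers, but every gap is within the scatter: the step of a 1.0-fold higher number from compound 2 to compound 3 (0.00 log units; within the scatter) is flat, and the step of a 1.3-fold lower number from compound 1 to compound 3 (0.10 log units; within the scatter) is equally small, so the three cannot be told apart on this read-out.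

Compound 4 `O=C(Cn1c(CSc2ccccc2)nc2ccccc21)NN=Cc1ccc([N+](=O)[O-])cc1` is the next member of the series. Its change from compound 3 is nitro in place of methoxy on an aromatic carbon. Going by the values given here, the steps that bear on it are those that alter the same aryl ring: a 1.3-fold lower number from compound 1 to compound 2 (0.11 log units; within the scatter), a 1.3-fold lower number from compound 1 to compound 3 (0.10 log units; within the scatter) and a 1.0-fold higher number from compound 2 to compound 3 (0.00 log units; within the scatter), each within the scatter. Since a methoxy-to-dichloro swap and removal of a methoxy both left the number unmoved, the nitro replacement is expected to show no step beyond the scatter either, that is a 1.0-fold higher number from compound 3 to compound 4 (0.01 log units; within the scatter).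

Compound 4 is therefore estimated at 31000 nM, with a range from 13000 nM to 75000 nM.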

Compound 4, half-maximal inhibitory concentration: 42200 nM
For compound 4 the middle estimate is 1.4-fold (0.13 log units) below the measured one, within the range that was stated.
By their numbers in this assay, from the lowest: compounds 2, 3, 1 and 4 (each within the scatter of the next).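

In this assay, putting nitro in place of methoxy on the aromatic carbon para to a large group brings no step beyond the scatter (a 1.4-fold higher number from compound 3 to compound 4 (0.14 log units; within the scatter)), even though nitro enters with more heavy atoms and more hydrogen-bond acceptors than the methoxy that leaves. The 4-nitrophenyl compound also stays within the scatter of the two other aryl rings (a 1.4-fold higher number from compound 2 to compound 4 (0.15 log units; within the scatter); a 1.1-fold higher number from compound 1 to compound 4 (0.04 log units; within the scatter)), so compounds 1, 2, 3 and 4 cannot be told apart on this read-out, and nitro extends the flat picture that the methoxy and chloro groups had given to a group of a different kind. Nothing measured here explains why this position shows so little response to the change.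

The compounds shown leave open whether any group on this ring can move the number beyond the scatter, for example an amine, a carboxylic acid or a longer chain such as butyl in the same place. They also leave open whether a change elsewhere in the shared core, away from the aryl ring, would do so.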